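This account rests on a few compounds, and the source may have more. Where it says the series, first, only, none or still open, it means among the compounds named here.

In an assay on isolated protein for inhibition of DNA topoisomerase 1 (Homo sapiens), with a stated time of 15 min (a higher number here means a weaker inhibitor, a lower number a stronger inhibitor), the measured compounds stand as follows:

Compound 1 `COc1c(N2CC[C@@H](CN)C2)c(F)cc2c(=O)c(C(=O)O)cn(Cc3cc(-c4ccccc4)no3)c12`: 178000 nM
Compound 2 `NC[C@@H]1CCN(c2cc3c(cc2F)c(=O)c(C(=O)O)cn3Cc2ccc(-c3ccc(F)cc3)cc2)C1`: 69600 nM
Compound 3 `COc1c(N2CC[C@@H](CN)C2)c(F)cc2c(=O)c(C(=O)O)cn(Cc3ccc(-c4ccc(F)cc4)cc3)c12`: 60900 nM

Compound 1 gives the highest of the three numbers; compound 2 is its nearest neighbour and compound 3 lies a little further off, both gaps beyond the scatter. Compound 3 and compound 2 differ in one place only: hydrogen in place of methoxy on an aromatic carbon. That change made a 1.1-fold higher number from compound 3 to compound 2 (0.06 log units; within the scatter). Compound 4 `NC[C@@H]1CCN(c2cc3c(cc2F)c(=O)c(C(=O)O)cn3Cc2cc(-c3ccccc3)no2)C1`, not yet measured, is obtained from compound 1 by the same change: hydrogen in place of methoxy on an aromatic carbon. The surroundings of the place are identical word for word in both cases. How the cores of compound 1 and compound 3 differ is not broken down here.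

For the measured compounds named here, since the only earlier example of this change stayed within the scatter, a similarly small step is expected for compound 4, a 1.1-fold higher number from compound 1 to compound 4 (0.03 log units; within the scatter), resting on a 1.1-fold higher number from compound 3 to compound 2 (0.06 log units; within the scatter). The estimate for compound 4 in this assay is 190000 nM, expected to fall between 90000 nM and 400000 nM.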

Compound 4, half-maximal inhibitory concentration: 58300 nM
Compound 4: the middle estimate sits 3.3-fold (0.51 log units) above what was measured, outside the stated range (below it).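

In this assay, putting hydrogen in place of methoxy gave a 3.1-fold lower number from compound 1 to compound 4 (0.48 log units; beyond the scatter), so the change did not behave alike on the two cores: the same change on two cores in this assay, a 1.1-fold higher number (0.06 log units; within the scatter) from compound 3 to compound 2 and a 3.1-fold lower number (0.48 log units; beyond the scatter) from compound 1 to compound 4, 3.5-fold (0.54 log units) apart, beyond the scatter of two such steps

In this small set, then, the step measured on one core was a poor guide to the step on the other. These two pairs do not show which structural difference between the cores goes with the gap, nor do they set a rule for the wider series.

The compounds shown leave open how an ethoxy group, a hydroxyl group or a chlorine atom at the same place would behave on each core. They also leave open whether any such group would show the same gap between the cores.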